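Carbamate chain extension from compound 3 to compound 4

This account rests on a few compounds, and the source may have more. Where it says the series, first, only, none or still open, it means among the compounds named here.

The series shares a core seen in compound 1 `COc1nc(C)c(Nc2nc(Cl)cn([C@H](COC(=O)c3ccccc3)C3CC3)c2=O)cc1C`, which in an assay on frontal cortex for displacement of a labelled ligand from corticotropin-releasing factor receptor 1 (Rattus norvegicus), with a stated time of 2 h (on this read-out higher numbers stand for weaker inhibition and lower numbers for stronger inhibition), gives 1.5 nM. Compound 2 `COc1nc(C)c(Nc2nc(Cl)cn([C@H](COC(=O)c3ccccn3)C3CC3)c2=O)cc1C` gives 67 nM, and compound 3 `CCNC(=O)OC[C@H](C1CC1)n1cc(Cl)nc(Nc2cc(C)c(OC)nc2C)c1=O` gives 14 nM. Among these three numbers compound 3 stands second highest: the step of a 9.3-fold higher number from compound 1 to compound 3 (0.97 log units; beyond the scatter) lies beyond the scatter, as does the step of a 4.8-fold lower number from compound 2 to compound 3 (0.68 log units; beyond the scatter). The step of a 45-fold higher number from compound 1 to compound 2 (1.65 log units; beyond the scatter) is the largest in the set.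

Compound 4 `CCCNC(=O)OC[C@H](C1CC1)n1cc(Cl)nc(Nc2cc(C)c(OC)nc2C)c1=O` differs from compound 3 by methyl in place of hydrogen on a saturated chain carbon, two bonds along the chain from an amide-type nitrogen, the same difference read one bond further out being ethylamino to propylamino. Among the compounds with values here, none of the measured steps bears directly on this change: each of them replaces the whole group on the carbonyl carbon, and the shift from phenyl to pyridin-2-yl or to ethylamino is of another kind than lengthening a saturated chain by one carbon. What the measured steps show is that the group on the carbonyl carbon matters, but they give no reading on a one-carbon extension within it. The expectation for compound 4 is therefore a step of no more than the scatter in this assay, with no direction preferred, as expressed by a 1.2-fold lower number from compound 3 to compound 4 (0.07 log units; within the scatter). Compound 4 is estimated at 12 nM, within a range from 4 nM to 35 nM.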

Compound 4, half-maximal inhibitory concentration: 10 nM
The estimate for compound 4 lay 1.2-fold (0.08 log units) above the measured number; low and high end bracket the measured number.
By their numbers in this assay, from the lowest: compound 1; then compounds 4 and 3 (each within the scatter of the next); then compound 2.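

In this assay the one-carbon extension of the chain on the carbamate, ethylamino to propylamino, gives a 1.4-fold lower number from compound 3 to compound 4 (0.15 log units; within the scatter) and so stays within the scatter, a reading on this saturated chain carbon that the earlier replacements of the whole group on the carbonyl carbon could not give. Against those aromatic groups, propylamino stands as ethylamino did: pyridin-2-yl to propylamino gives a 6.7-fold lower number from compound 2 to compound 4 (0.83 log units; beyond the scatter) and phenyl to propylamino gives a 6.7-fold higher number from compound 1 to compound 4 (0.82 log units; beyond the scatter), both beyond the scatter, so the single added methyl leaves the gaps to compound 1 and compound 2 in place. The data shown offer no explanation for this result.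

Still open, as far as these compounds go, is whether the flat reading holds for a butylamino group or a longer chain, or for branched or cyclic groups such as isopropylamino and cyclopropylamino on the carbonyl carbon. Also open, from the compounds shown here alone, is whether a benzylamino or anilino group, which would bring a phenyl ring back onto the carbamate nitrogen, would narrow the gap to the benzoate ester of compound 1.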